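Notes on the step from compound 2 to compound 4

The source may report more compounds than this note shows. Statements on the series, on what has been measured and on what is new or still open speak of the compounds shown alone.

In a physicochemical assay for solubility, in phosphate buffer, measured as kinetic solubility (on this read-out higher numbers stand for higher solubility and lower numbers for lower solubility), compound 2 `CC(C)[C@@H](c1ccc(-c2ccc3cccc(F)c3c2)[nH]c1=O)[C@@H]1OC(=O)NC1=O` gives 27400 nM and stands within the scatter of compound 1 `Cc1cc(C(/C=C2\OC(=O)NC2=O)C(C)C)c(=O)[nH]c1-c1ccc2cccc(F)c2c1` at 35700 nM in the same read-out. Compound 3 `CC(C)C(c1ccc(-c2ccc3cccc(F)c3c2)[nH]c1=O)C1NC(=O)NC1=O` gives 10600 nM and lies lower than compound 2, beyond the scatter. Compound 4 `CC(C)[C@H](C[C@H]1OC(=O)NC1=O)c1ccc(-c2ccc3cccc(F)c3c2)[nH]c1=O` carries (2,4-dioxo-1,3-oxazolidin-5-yl)methyl in place of 2,4-dioxo-1,3-oxazolidin-5-yl on a saturated chain carbon bound to an aromatic carbon and a saturated chain carbon. Going by the values given here, no measured pair here differs in one place, and the expectation rests on the structural change alone. A small move to lower numbers in this assay is expected, within the scatter (a 1.2-fold lower number from compound 2 to compound 4 (0.10 log units; within the scatter)). The estimate for compound 4 is 22000 nM with 9000 nM to 45000 nM as the expected range.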

Compound 4, solubility: 35400 nM
Compound 4: the middle estimate sits 1.6-fold (0.21 log units) below what was measured, and the stated range covers the measured number.
By their numbers in this assay, from the lowest: compound 3; then compounds 2, 4 and 1 (each within the scatter of the next).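

In this assay, going by these compounds alone, (2,4-dioxo-1,3-oxazolidin-5-yl)methyl in place of 2,4-dioxo-1,3-oxazolidin-5-yl on a saturated chain carbon bound to an aromatic carbon and a saturated chain carbon gives a 1.3-fold higher number from compound 2 to compound 4 (0.11 log units; within the scatter) and provides the only single-place comparison. At this position, the one added carbon therefore produces no resolved difference in this read-out. Nothing measured here accounts for the step.

The compounds shown leave open whether an amine or a carboxylic acid at this place, or a longer chain carrying the same ring, would also remain within the scatter of compound 2.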